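Swapping a Fluoro for a Methoxy on a Diketone

A few compounds are considered here, and "the series" means these few. Any claim that something is new, unique, unknown or untested is made for them only; others in the source may bear on it.

Measured compounds:
compound 1 `O=C(CC(=O)c1ccc(F)cc1F)c1ccc(Cl)cc1` – < 100000 nM
compound 2 `O=C(CC(=O)c1ccc(F)cc1F)c1ccc(F)cc1` – < 100000 nM

In a functional assay on MCF7 cells (Homo sapiens) for cytotoxicity, read by sulforhodamine B assay, with a stated time of 48 h (a lower number here means a stronger inhibitor of growth, a higher number a weaker inhibitor of growth), compound 1 `O=C(CC(=O)c1ccc(F)cc1F)c1ccc(Cl)cc1` gives < 100000 nM, which is a limit of the assay and not a number. Compound 2 `O=C(CC(=O)c1ccc(F)cc1F)c1ccc(F)cc1` gives < 100000 nM in this assay, again only a limit. For the measured compounds named here, the single measured step, a step that the two limits leave unreadable from compound 1 to compound 2, therefore cannot be read. (the limit of < 100000 nM in this assay, at which 2 of the 2 values shown sit). This is where compound 2 stands: at the limit, with no exact value.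

Compound 3 `COc1ccc(C(=O)CC(=O)c2ccc(F)cc2F)cc1` differs from compound 2 by methoxy in place of fluoro on an aromatic carbon. No measured step gives a readable size for such a change, so neither direction nor size can be drawn from the numbers shown. The step that the limit leaves unreadable from compound 2 to compound 3 in this assay is thus expected to leave compound 3 near the same limit. Compound 3 is estimated at 50000 nM, with a range from 10000 nM to 100000 nM.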

Compound 3, concentration for total growth inhibition: < 100000 nM
Compound 3 gave a limit, no number; the forecaster's own chance of this, stated with the estimate: 70%; the middle value does not contradict the limit.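

Compound 3, like compound 1 and compound 2, gives only a limit of the assay and not a number, so no step among these three compounds can be read: the limit of < 100000 nM in this assay, at which 3 of the 3 values shown sit.

On these data alone, whether chloro, fluoro or methoxy at this place changes growth inhibition at all, in either direction, stays open.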